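This account rests on a few compounds, and the source may have more. Where it says the series, first, only, none or still open, it means among the compounds named here.

Working notes on a short series built on one shared core. Among the compounds with values here, compound 1 `Nc1nn2c(O)cc(-c3ccccc3)nc2c1[N+](=O)[O-]` and compound 2 `Nc1nn2c(O)cc(CNNCCO)nc2c1[N+](=O)[O-]` are the two measured members, both run in a functional assay on K562 cells (Homo sapiens) for inhibition; on this read-out higher numbers stand for weaker inhibition of growth and lower numbers for stronger inhibition of growth. For compound 1 the result in this assay is a limit of the assay, > 50 ug/mL. For compound 2 the result in this assay is likewise a limit of the assay, > 50 ug/mL. The step that the two limits leave unreadable from compound 1 to compound 2 therefore cannot be read in size. Both known results sit at the limit of > 50 ug/mL in this assay, at which 2 of the 2 values shown sit, so compound 2 stands at that limit and nothing finer is known about it.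

Compound 3 `Nc1nn2c(O)cc(CNCCO)nc2c1[N+](=O)[O-]` differs from compound 2 by 2-hydroxyethyl in place of (2-hydroxyethyl)amino on an amine nitrogen. Within the data shown here, no measured step bears directly on this change: the single step, a step that the two limits leave unreadable from compound 1 to compound 2, is a different change and is itself unreadable. With both known members at the limit, compound 3 is expected to remain at or near it, the expected step being a step that the limit leaves unreadable from compound 2 to compound 3. For compound 3 in this assay the estimate is 60 ug/mL, with a range from 20 ug/mL to 180 ug/mL.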

Compound 3, concentration for 50% growth inhibition: > 50 ug/mL
Compound 3: no number, only a limit; the forecaster's own chance of this, stated with the estimate: 75%; the middle value lies beyond the limit too.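

Compound 3 yields only a limit in this assay, as do compound 1 and compound 2, so no new step can be read in size among the three: the limit of > 50 ug/mL in this assay, at which 3 of the 3 values shown sit. The compounds shown leave open whether any change on the shared core shifts growth inhibition at all, and how large such a shift would be.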